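The compounds below may be only part of what the source reports. "The series", "measured", "known", "first", "only" and "open" are said of these compounds alone.

Three compounds sharing one core were measured in a functional assay on HeLa cells (Homo sapiens) for antiproliferative activity, read by CCK-8 assay, with a stated time of 72 h, tested at 2 uM; on this read-out higher numbers stand for a stronger effect at the one concentration tested and lower numbers for a weaker effect. Compound 1 `Nc1ccccc1NC(=O)c1ccc(CSC(=S)N2CCc3cc([N+](=O)[O-])ccc32)cc1` gives 32.6% in this assay, and compound 3 `Nc1ccccc1NC(=O)c1ccc(CSC(=S)N2CCc3ccc([N+](=O)[O-])cc32)cc1` gives 45.7%. Compound 2 `CCN(Cc1ccncc1)C(=S)SCc1ccc(C(=O)Nc2ccccc2N)cc1` stands highest of the three numbers with 63.5%; compound 3 is its nearest neighbour, lower by a gap beyond the scatter, and compound 1 lies furthest below, also beyond the scatter. Compound 4 `CN(Cc1cccnc1)C(=S)SCc1ccc(C(=O)Nc2ccccc2N)cc1` differs from compound 2 in one place: methyl((pyridin-3-yl)methyl)amino in place of ethyl((pyridin-4-yl)methyl)amino on a thiocarbonyl carbon. Within the data shown here, no measured pair isolates this change, so its effect is unknown. The step expected from compound 2 to compound 4 in this assay is small and, if anything, downward, possibly none beyond the scatter: a number 8.5 percentage points lower from compound 2 to compound 4 (within the scatter). Compound 4 is therefore estimated at 55%, in a range from 35% to 72%.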

Compound 4, a percentage reported as inhibition, at one concentration (the size of the read-out at that concentration, not a potency): 16.4%
Compound 4: middle estimate off by 38.6 percentage points, on the high side, and the stated range ends above it.
By their numbers in this assay, from the lowest: compound 4; then compound 1; then compound 3; then compound 2.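

On a thiocarbonyl carbon, methyl((pyridin-3-yl)methyl)amino in place of ethyl((pyridin-4-yl)methyl)amino gives in this assay a large loss, a number 47.1 percentage points lower from compound 2 to compound 4 (beyond the scatter), so this position is far from indifferent to a change of modest size. Nothing available bears on the reason for this loss. The step alters the alkyl group and the pyridine attachment together, and the compounds shown cannot tell which of the two carries the loss. Methyl((pyridin-4-yl)methyl)amino or ethyl((pyridin-3-yl)methyl)amino on the same carbon would separate the two.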